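The source may hold more compounds than are shown below. What is called first, only, known or untested is meant among the compounds shown, and "the series" means these compounds.

Two compounds of a shared core carrying a long chain that ends in a ring with a hydroxyl group have already been tested. Compound 1 `O=c1cc(-c2ccccc2)oc2ccc(OCCCCCCN3CCCC(O)C3)cc12` gives 77 nM in an assay on isolated protein (Cavia porcellus) with Sigma non-opioid intracellular receptor 1 (Homo sapiens) as the target, read by radioligand binding; on this read-out higher numbers stand for weaker inhibition and lower numbers for stronger inhibition. Compound 2 `O=c1cc(-c2ccccc2Cl)oc2ccc(OCCCCCCN3CCC(O)CC3)cc12` gives 29 nM in this assay, and this is the lower of the two numbers, with the number for compound 1 standing above it by more than the usual scatter. Going by the values given here, compound 1 and compound 2 differ in two places at once, so the two values show only that compound 2 binds more strongly, not what each change contributes.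

Compound 3 `O=c1cc(-c2ccncc2)oc2ccc(OCCCCCCN3CCC(O)CC3)cc12` has not yet been measured. It differs from compound 2 in one place: pyridin-4-yl in place of 2-chlorophenyl on an aromatic carbon. Among the compounds with values here, no pair of measured compounds shows this kind of change, so there is no step to lean on. A change of this kind is expected to weaken binding, so the step of a 3.1-fold higher number from compound 2 to compound 3 (0.49 log units; beyond the scatter) is expected to go toward a higher number, likely beyond the scatter. Compound 3 is therefore estimated at 90 nM in this assay, within a range from 30 nM to 300 nM.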

Compound 3, half-maximal inhibitory concentration: 308 nM
For compound 3 the middle estimate is 3.4-fold (0.53 log units) below the measured one, outside the stated range (above it).
By their numbers in this assay, from the lowest: compound 2; then compound 1; then compound 3.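

In this assay, putting pyridin-4-yl in place of 2-chlorophenyl on the aromatic carbon next to the ring oxygen gives an 11-fold higher number from compound 2 to compound 3 (1.03 log units; beyond the scatter), a large step and the first change in a single place seen among these compounds. With the rest of the molecule the same, this shows that binding is sensitive to which aromatic ring sits at this position, and that the long chain and its hydroxyl-bearing ring do not keep binding strong on their own. The change swaps a carbon-only ring bearing chlorine for a ring with one nitrogen, and nothing measured here explains the size of the step.

In this pair the chlorine leaves and a ring nitrogen enters at once. The data cannot tell these two parts of the change apart. Groups such as pyridin-3-yl or 2-fluorophenyl at the same position, on the chain of compound 2, would help separate these two parts and show whether the position's sensitivity extends beyond this one swap.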